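This account rests on a few compounds, and the source may have more. Where it says the series, first, only, none or still open, it means among the compounds named here.

Of the compounds shown here, two built on a shared core have been measured in a functional assay on FaDu cells (Homo sapiens) for activation, read by microscopy, with a stated time of 7 days; on this read-out higher numbers stand for an effect only at larger amounts of compound and lower numbers for an effect already at smaller amounts. Compound 1 `COCCn1cc(C(=O)C(=O)Nc2ccc(OC(C)C)nc2)c2ccccc21` gives 113 nM in this assay. Compound 2 `COCC(C)n1cc(C(=O)C(=O)Nc2ccc(OC)nc2)c2ccccc21` gives 39 nM in this assay, the lowest of the two numbers, with compound 1 as its nearest neighbour and that gap beyond the scatter. Compound 3 `COc1ccc(NC(=O)C(=O)c2cn(CC3CCCO3)c3ccccc23)cn1` is not yet measured; it differs from compound 2 in one place: (oxolan-2-yl)methyl in place of 1-(methoxymethyl)ethyl on an aromatic nitrogen. Within the data shown here, no measured pair shows a change of this kind, so the step of a 1.3-fold higher number from compound 2 to compound 3 (0.11 log units; within the scatter) is expected to be small and within the scatter. Compound 3 is estimated at 50 nM, with a range from 18 nM to 150 nM.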

Compound 3, half-maximal effective concentration: 77 nM
Estimate against measurement, compound 3: 1.5-fold (0.19 log units) below; the measured number falls inside the stated range.
By their numbers in this assay, from the lowest: compounds 2, 3 and 1 (each within the scatter of the next, the first and the last beyond it).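

In this assay, putting (oxolan-2-yl)methyl in place of 1-(methoxymethyl)ethyl on the aromatic nitrogen gives a 2.0-fold higher number from compound 2 to compound 3 (0.30 log units; within the scatter), the first step read at this position. A five-membered non-aromatic ring with one hetero atom can therefore stand there without a change beyond the scatter, while the hydrogen-bond acceptor count stays the same. Nothing available explains the size of this step. The compounds shown leave open what an amine, a carboxylic acid or a longer chain would give on this nitrogen.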